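The source may report more compounds than this note shows. Statements on the series, on what has been measured and on what is new or still open speak of the compounds shown alone.

Measured so far:
Compound 1 `O=C(CI)NCCCCCC(=O)NCCCNc1ncnc2c1ncn2[C@@H]1O[C@H](COP(=O)(O)OP(=O)(O)OP(=O)(O)O)[C@@H](O)[C@H]1O`: 0%
Compound 2 `O=C(CI)NCCC(=O)NCCCCCCNc1ncnc2c1ncn2[C@@H]1O[C@H](COP(=O)(O)OP(=O)(O)OP(=O)(O)O)[C@@H](O)[C@H]1O`: 0%

In an assay on isolated protein for inhibition of hexokinase-1 (Rattus norvegicus), with a stated time of 6 h, tested at 10 mM (a higher number here means more inhibition at the concentration tested (going by the name of the read-out), a lower number less inhibition), compound 1 gives 0%. In this assay compound 2 gives 0%, level with compound 1 at the digits shown, a difference within the usual scatter; nothing separates the two.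

Compound 3 `O=C(I)NCC(=O)NCCCCCCNc1ncnc2c1ncn2[C@@H]1O[C@H](COP(=O)(O)OP(=O)(O)OP(=O)(O)O)[C@@H](O)[C@H]1O` is not yet measured. It differs from compound 2 in one place: a group of 4 heavy atoms (1 carbon, 1 nitrogen, 1 oxygen, 1 iodine; no ring) in place of a group of 6 heavy atoms (3 carbon, 1 nitrogen, 1 oxygen, 1 iodine; no ring), on a saturated chain carbon bound to a carbonyl carbon.

With both measured compounds showing no inhibition, a shorter chain of the same kind gives no reason to expect a different outcome. The step from compound 2 to compound 3 is expected to be a number 2 percentage points higher from compound 2 to compound 3 (within the scatter), no change beyond the scatter. For compound 3 the expected value in this assay is 2%, between 0% and 15%.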

Compound 3, a percentage reported as inhibition, at one concentration (the size of the read-out at that concentration, not a potency): 0%
Beside the measured number, compound 3's estimate is 2 percentage points above it; the measured number falls inside the stated range.
By their numbers in this assay, from the lowest: compounds 1, 2 and 3 (each within the scatter of the next).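

In this assay, exchanging the (((iodomethyl)carbonyl)amino)methyl group for the smaller group of 4 heavy atoms gives no change at the digits printed from compound 2 to compound 3 (within the scatter). So, on a saturated chain carbon bound to a carbonyl carbon, this smaller group brings no inhibition into view at the concentration tested, just as the larger group did. No supporting measurement is available to explain this result.

With every compound shown reading the same, it remains open whether any group at this place can give measurable inhibition. A longer chain, an amine or a carboxylic acid there remains untested in the compounds shown.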